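This account rests on a few compounds, and the source may have more. Where it says the series, first, only, none or still open, it means among the compounds named here.

Compound 1, `CS(=O)(=O)Nc1cccc2c1CCC2c1ncc[nH]1`: 87% in a functional assay on CHO cells for agonist activity at Alpha-1A adrenergic receptor (Homo sapiens), read by FLIPR and calcium flux; a higher number here means a larger maximal response, a lower number a smaller maximal response
Compound 2, `c1cc(-c2cn[nH]c2)c2c(c1)C(c1ncc[nH]1)CC2`: 84%
Compound 3, `c1ccc(-c2cccc3c2CCC3c2ncc[nH]2)nc1`: 53%

Compound 3 stands lowest of the three in this assay. Its nearest neighbour is compound 2, and the step of a number 31 percentage points lower from compound 2 to compound 3 (beyond the scatter) lies beyond the scatter; the step from compound 1, a number 34 percentage points lower from compound 1 to compound 3 (beyond the scatter), is larger still. Compounds 1 and 2, by contrast, sit close together: a number 3 percentage points lower from compound 1 to compound 2 (within the scatter).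

Compound 4, `CNC(=O)c1cccc2c1CCC2c1ncc[nH]1`, has not yet been measured. It differs from compound 3 in one place: methylcarbamoyl in place of pyridin-2-yl on an aromatic carbon. The entering methylcarbamoyl carries no ring, whereas the leaving pyridin-2-yl is a six-membered aromatic ring with one hetero atom.

Within the data shown here, two measured steps bear on this change. Both times a pyridin-2-yl was put onto this aromatic carbon, in place of methanesulfonamido or of 1H-pyrazol-4-yl, the maximal response fell by a large amount, a number 34 percentage points lower from compound 1 to compound 3 (beyond the scatter) and a number 31 percentage points lower from compound 2 to compound 3 (beyond the scatter). Removing the pyridin-2-yl again is therefore expected to reverse most of that drop, with a large upward step, a number 29 percentage points higher from compound 3 to compound 4 (beyond the scatter), bringing compound 4 back toward the level of compounds 1 and 2. For compound 4 the estimated value in this assay is 82%, with a range from 65% to 95%.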

Compound 4, largest response reached (Emax), in percent of the reference or control that the assay uses: 59%
Beside the measured number, compound 4's estimate is 23 percentage points above it; measured number outside the range, below it.
By their numbers in this assay, from the lowest: compounds 3 and 4 (each within the scatter of the next); then compounds 2 and 1 (each within the scatter of the next).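

In this assay taking away the pyridin-2-yl does not by itself bring the response back: putting methylcarbamoyl on this aromatic carbon gives a number 6 percentage points higher from compound 3 to compound 4 (within the scatter) even though the entering group has no ring and carries a hydrogen-bond donor that the leaving group lacks. The low level is therefore not peculiar to pyridin-2-yl, since the methylcarbamoyl also stands apart from both groups at the upper level, with a number 25 percentage points lower from compound 2 to compound 4 (beyond the scatter) and a number 28 percentage points lower from compound 1 to compound 4 (beyond the scatter) as the two steps. Having a ring does not sort these compounds either: ringless methanesulfonamido in compound 1 and ring-bearing 1H-pyrazol-4-yl in compound 2 sit together at the upper level, while ring-bearing pyridin-2-yl in compound 3 and ringless methylcarbamoyl in compound 4 sit together at the lower one.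

The compounds shown leave open where an amine or a carboxylic acid on this aromatic carbon would fall, and so what separates the two upper groups from the two lower groups. No supporting data explain this split in maximal response.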